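This account rests on a few compounds, and the source may have more. Where it says the series, first, only, none or still open, it means among the compounds named here.

Measured compounds:
compound 1, `CCCNC(=O)NS(=O)(=O)c1ccc(-n2nc(-c3ccccc3)ccc2=O)cc1`: 125%
compound 2, `CCCNC(=O)NS(=O)(=O)c1ccc(-n2nc(-c3ccc(C)cc3)ccc2=O)cc1`: 109%
compound 3, `O=C(NC1CCCCC1)NS(=O)(=O)c1ccc(-n2nc(-c3ccc(Cl)cc3)ccc2=O)cc1`: 114%

All values come from a functional assay on the whole organism (blood, strain Wistar albino) for inhibition, with Rattus norvegicus as the target, read by colorimetric assay, with stated times of 15 min and 90 min, at a dose of 20 mg/kg by the oral route; on this read-out higher numbers stand for more inhibition at the one dose given (going by the name of the read-out) and lower numbers for less inhibition. Compound 4, `Cc1cc(-c2ccc(=O)n(-c3ccc(S(=O)(=O)NC(=O)NC4CCCCC4)cc3)n2)ccc1Cl`, is not yet measured. Compound 4 differs from compound 3 by methyl in place of hydrogen on an aromatic carbon. The same change from compound 1 to compound 2 reads methyl in place of hydrogen on an aromatic carbon and gave a number 16 percentage points lower from compound 1 to compound 2 (beyond the scatter). The surroundings are not identical: in compound 2 the methyl stands para to a large group, in compound 4 ortho to a chloro group and meta to a large group, so this is the same kind of change, not the same. How the core of compound 3 differs from the core of compound 1 is not broken down here. Compound 3 and compound 2 lie within the scatter of each other. Going by the values given here, for compound 4 a step of the same direction and like or somewhat smaller size is expected, a number 11 percentage points lower from compound 3 to compound 4 (beyond the scatter), because a number 16 percentage points lower from compound 1 to compound 2 (beyond the scatter) is the only guide for this change. Compound 4 is therefore estimated at 103%, between 90% and 118%.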

Compound 4, a percentage reported as inhibition, in the whole organism at one dose (the size of the read-out at that dose, not a potency): 55.2%
Estimate against measurement, compound 4: 47.8 percentage points above; the measured number lies below the stated range.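

The change from 4-chlorophenyl to 4-chloro-3-methylphenyl gives a number 58.8 percentage points lower from compound 3 to compound 4 (beyond the scatter). In this assay, methyl in place of hydrogen keeps its direction on both cores, but the size of the step does not carry over: the same change on two cores in this assay, a number 16 percentage points lower (beyond the scatter) from compound 1 to compound 2 and a number 58.8 percentage points lower (beyond the scatter) from compound 3 to compound 4, 42.8 percentage points apart, beyond the scatter of two such steps These two steps do not show whether the core or the surroundings of the methyl, which stands ortho to a chloro group in compound 4, sets the size, so a step from one core cannot yet size the same change on another.

Open, from the compounds shown here alone, is how the 4-chloro-3-methylphenyl group reads on the core of compound 1. Also open, going by these compounds, is whether a fluoro or a methoxy group in the place of this methyl gives a step of like size.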